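Adding an Amino Group to Compound 1: Expected Cytotoxicity

This account rests on a few compounds, and the source may have more. Where it says the series, first, only, none or still open, it means among the compounds named here.

Among the measured compounds shown here, compound 1 `ClCc1ccc(Cn2cnc3c(Cl)ncnc32)cc1` holds the higher of the two numbers known so far: in a functional assay on TK-10 cells (Homo sapiens) for cytotoxicity, read by sulforhodamine B assay, with a stated time of 48 h (on this read-out higher numbers stand for lower toxicity in this test and lower numbers for higher toxicity in this test), compound 1 gives 22900 nM. For the measured compounds named here, the only other measured compound, compound 2 `ClCc1ccccc1Cn1cnc2c(Cl)nc(Cl)nc21`, differs from it in several places and gives 5620 nM in this assay, a lower number that lies beyond the usual scatter. Compound 3 `Nc1nc(Cl)c2ncn(Cc3ccc(CCl)cc3)c2n1` has not yet been tested. It differs from compound 1 in one way: amino in place of hydrogen on an aromatic carbon. Going by the values given here, no measured pair shows this change on its own, so there is no directly comparable step to lean on. Without such a precedent, the author expects the step from compound 1 to compound 3 in this assay to be small, a 1.1-fold higher number from compound 1 to compound 3 (0.04 log units; within the scatter), most likely within the scatter and of uncertain direction. On that basis compound 3 is expected to give about 25000 nM in this assay, with a plausible range from 8000 nM to 70000 nM.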

Compound 3, concentration lethal to 50% of the cells: 97700 nM
Compound 3: the middle estimate sits 3.9-fold (0.59 log units) below what was measured; the whole stated range lies below it.
By their numbers in this assay, from the lowest: compound 2; then compound 1; then compound 3.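

In this assay, placing amino on the aromatic carbon between two ring nitrogen atoms gives a 4.3-fold higher number from compound 1 to compound 3 (0.63 log units; beyond the scatter), a step beyond the scatter towards lower toxicity in this test. As the only single-place step shown, it indicates that this position, which bears hydrogen in compound 1, is not indifferent to change in this test. Nothing available bears on the reason for this step.

From the compounds shown here alone, it remains open whether a methylamino group, a hydroxyl group or a methoxy group at the same position would shift the number in the same direction and to a similar extent. Going by these compounds, it is also open whether amino would have a comparable effect on a compound carrying its chloromethyl group in the arrangement seen in compound 2.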